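Fluoro-for-hydrogen step across two cores

This account rests on a few compounds, and the source may have more. Where it says the series, first, only, none or still open, it means among the compounds named here.

Measured in a functional assay on A-431 cells (Homo sapiens) for cytotoxicity, read by MTT assay, with a stated time of 72 h, tested at 100 uM; a lower number here means less inhibition of growth, a higher number more inhibition of growth at the concentration tested:
- compound 1, `N/C(=N\NC(=S)N1CCCCCC1)c1ccccn1`: 77.5%
- compound 2, `N/C(=N\NC(=S)N1CCSCC1)c1ccccn1`: 80.8%
- compound 3, `N/C(=N\NC(=S)N1CCSCC1)c1ccc(F)cn1`: 86.6%

Compound 2 and compound 3 share one core, compound 1 and compound 4 another; the difference between the two cores is not broken down here. Compound 1 and compound 2 sit within the scatter of each other in this assay, as do compound 1 and compound 3. Going from compound 2 to compound 3 the change is fluoro in place of hydrogen on an aromatic carbon, and it made a number 5.8 percentage points higher from compound 2 to compound 3 (within the scatter). Compound 4, `N/C(=N\NC(=S)N1CCCCCC1)c1ccc(F)cn1`, is compound 1 carrying the same change, (fluoro in place of hydrogen on an aromatic carbon). In this assay, going by the values given here, compound 4 is expected to move by about a number 4.5 percentage points higher from compound 1 to compound 4 (within the scatter), a step of the same small size, because a number 5.8 percentage points higher from compound 2 to compound 3 (within the scatter) was the only instance of this change observed. Compound 4 is therefore estimated at 82%, with the likely range from 70% to 93%.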

Compound 4, percent growth inhibition at one concentration: 83.5%
Compound 4: the middle estimate sits 1.5 percentage points below what was measured; the range from low to high includes it.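

In this assay, the fluoro-for-hydrogen change on the core of compound 1 gives a number 6 percentage points higher from compound 1 to compound 4 (within the scatter). Set beside the earlier step, the change carries over between the two cores at the same small size: the same change on two cores in this assay, a number 5.8 percentage points higher (within the scatter) from compound 2 to compound 3 and a number 6 percentage points higher (within the scatter) from compound 1 to compound 4, 0.2 percentage points apart, within the scatter of two such steps. Going by these compounds alone, both steps lie within the scatter, so this agreement shows only that neither core gives a readable step at this single concentration; it does not show that fluoro itself alters growth inhibition, nor that the match would hold on any further core.

The compounds shown carry only fluoro at this place, two atoms from the ring nitrogen, so the outcome with chloro, methoxy or an amine there remains open. Going by these compounds, whether any step between these compounds would emerge in a full concentration series also remains open.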